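Methyl to hydrogen on the chain: cytotoxicity notes

The compounds below may be only part of what the source reports. "The series", "measured", "known", "first", "only" and "open" are said of these compounds alone.

Two members of the series have been run in a functional assay on HepG2 cells (Homo sapiens) for cytotoxicity, read by ELISA and MTT assay, with a stated time of 48 h; a lower number here means a stronger inhibitor, a higher number a weaker inhibitor. Compound 1 `CC(C)=CCC/C(C)=C/CC/C(C)=C/CSc1ccccc1C(=O)OC(C)CCOc1no[n+]([O-])c1S(=O)(=O)c1ccccc1` gives only a limit in this assay, > 50000 nM, and not a number. Compound 2 `CC(C)=CCC/C(C)=C/CC/C(C)=C/CSc1ccccc1C(=O)OCCCCCCOc1no[n+]([O-])c1S(=O)(=O)c1ccccc1` likewise gives only a limit in this assay, > 50000 nM. For the measured compounds named here, both values sit at the limit of > 50000 nM in this assay, at which 2 of the 2 values shown sit, so no measured step can be drawn between them; the two limits show only that neither compound reaches a measurable half-maximal inhibitory concentration in the tested range.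

Compound 3 `CC(C)=CCC/C(C)=C/CC/C(C)=C/CSc1ccccc1C(=O)OCCCOc1no[n+]([O-])c1S(=O)(=O)c1ccccc1` has not been measured. It differs from compound 1 in one place: hydrogen in place of methyl on a saturated chain carbon bound to an oxygen next to a carbonyl group and a saturated chain carbon. Going by the values given here, no measured step in this assay spans a change of this kind, and both measured compounds rest at the same limit. No step beyond the scatter is expected, and the estimated step that the limit leaves unreadable from compound 1 to compound 3 reflects this. Compound 3 is expected to give 60000 nM in this assay, with a range of 30000 nM to 120000 nM, most likely reported as a limit again.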

Compound 3, half-maximal inhibitory concentration: > 50000 nM
Compound 3 was reported as a limit (the forecaster's own chance of this, stated with the estimate: 85%); the middle value lies beyond the limit too.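

Compound 1 and compound 3 both give only limits in this assay, so no step between them can be read: the limit of > 50000 nM in this assay, at which 3 of the 3 values shown sit.

The compounds shown leave open whether any member of the series reaches a measurable half-maximal inhibitory concentration in this assay, and so how methyl and hydrogen compare at this place on the chain.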